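The source may hold more compounds than are shown below. What is called first, only, known or untested is meant among the compounds shown, and "the series" means these compounds.

Measured so far in an ADME assay on BJ cells (Homo sapiens) for inhibition, with a stated time of 72 h; on this read-out lower numbers stand for an effect already at smaller amounts and higher numbers for an effect only at larger amounts of compound:
compound 1 `C/C=C/C(=O)Nc1cccc(-c2nc3ccccc3s2)c1` — > 25000 nM
compound 2 `O=C(O)/C=C/C(=O)Nc1cccc(-c2nc3ccccc3s2)c1` — > 25000 nM
compound 3 `O=C(Nc1cccc(-c2nc3ccccc3s2)c1)c1cccnc1Cl` — > 25000 nM

In this assay compound 1 gives > 25000 nM, which is a limit of the assay and not a number. Compound 2 likewise sits at a limit, > 25000 nM. Compound 3 also reports only a limit, > 25000 nM. All three values therefore sit at the limit of > 25000 nM in this assay, at which 3 of the 3 values shown sit, and the steps a step that the two limits leave unreadable from compound 1 to compound 2, a step that the two limits leave unreadable from compound 1 to compound 3 and a step that the two limits leave unreadable from compound 2 to compound 3 cannot be read.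

Compound 4 `O=C(Nc1cccc(-c2nc3ccccc3s2)c1)c1ccnc(Cl)c1` is still to be measured. Against compound 1 the change is 2-chloropyridin-4-yl in place of prop-1-en-1-yl on a carbonyl carbon. The step from compound 1 to compound 3 is the closest comparison, but it is unreadable. Among the compounds with values here, no step shows a measurable effect, so the step that the limit leaves unreadable from compound 1 to compound 4 is expected to leave compound 4 at the limit as well. Compound 4 is estimated at 30000 nM, between 12000 nM and 100000 nM.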

Compound 4, half-maximal effective concentration: > 25000 nM
Compound 4: no number, only a limit; the forecaster's own chance of this, stated with the estimate: 85%; the middle value lies beyond the limit too.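

In this assay compound 4 gives > 25000 nM as a limit and not a number. The steps from compound 4 to compounds 1, 2 and 3 therefore cannot be read: the limit of > 25000 nM in this assay, at which 4 of the 4 values shown sit.
Whether any group on the carbonyl carbon gives a measurable value in this assay stays open across the compounds shown.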